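The source may report more compounds than this note shows. Statements on the series, on what has been measured and on what is new or still open speak of the compounds shown alone.

Working notes on the series, read in a functional assay on a cell-free system (plasma, Homo sapiens), with a stated time of 3 min; on this read-out higher numbers stand for weaker inhibition and lower numbers for stronger inhibition. Compound 1 (`O=C(NCc1cc(Cl)ccc1-n1cnnn1)[C@@H]1CC=NN1C(=O)[C@H](O)c1ccccc1`) gives 840 nM and compound 2 (`CC(C)(C)[C@@H](O)C(=O)N1[C@@H]2C[C@@H]2C[C@H]1C(=O)NCc1cc(Cl)ccc1-n1cnnn1`) gives 1100 nM. These two numbers lie within the scatter of each other, so compound 1 is not separated from compound 2. Compound 3 (`COC(C)(C)[C@@H](O)C(=O)N1N=CC[C@H]1C(=O)NCc1cc(Cl)ccc1-n1cnnn1`) carries 1-methoxy-1-methylethyl in place of phenyl on a saturated chain carbon bound to a carbonyl carbon and an oxygen on a saturated carbon. Within the data shown here, no measured step covers this change. Compound 2 also lacks the phenyl yet gives 1100 nM, so only a small move toward weaker inhibition is expected. The expected step is a 1.8-fold higher number from compound 1 to compound 3 (0.25 log units; within the scatter). Compound 3 is estimated at 1500 nM, with a range of 500 nM to 4500 nM.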

Compound 3, half-maximal inhibitory concentration: 3700 nM
Compound 3: the middle estimate sits 2.5-fold (0.39 log units) below what was measured; low and high end bracket the measured number.
By their numbers in this assay, from the lowest: compounds 1 and 2 (each within the scatter of the next); then compound 3.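

In this assay, among these compounds, 1-methoxy-1-methylethyl in place of phenyl on a saturated chain carbon bound to a carbonyl carbon and an oxygen on a saturated carbon gives a 4.4-fold higher number from compound 1 to compound 3 (0.64 log units; beyond the scatter) and is the first measured change at this position. The position therefore does not accept every group alike, and this open-chain replacement gives weaker inhibition than phenyl. No supporting data explain the step. Going by these compounds, what cyclohexyl or pyridyl would give at this position stays open. Also open, on these data alone, is whether the step follows from losing the phenyl ring or from gaining the methoxy oxygen.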